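The source may hold more compounds than are shown below. What is called first, only, known or untested is meant among the compounds shown, and "the series" means these compounds.

Three compounds built on one shared core differ only in the group attached to the sulfur. Compound 1 `CCC(Sc1nc2c(cnn2C)c(=O)n1-c1ccccc1)c1ccccc1` carries a 1-phenylpropyl group, compound 2 `CC(Sc1nc2c(cnn2C)c(=O)n1-c1ccccc1)c1ccncc1` a 1-(pyridin-4-yl)ethyl group, and compound 3 `CC(Sc1nc2c(cnn2C)c(=O)n1-c1ccccc1)c1cccc(O)c1` a 1-(3-hydroxyphenyl)ethyl group. In an assay on isolated protein for inhibition of aldehyde dehydrogenase 1A1 (Homo sapiens) (a lower number here means a stronger inhibitor, a higher number a weaker inhibitor), compound 1 gives 150 nM, compound 2 gives 451 nM, and compound 3 gives 130 nM. Compound 3 and compound 1 sit close together, as a 1.2-fold lower number from compound 1 to compound 3 (0.06 log units; within the scatter) shows, whereas a 3.0-fold higher number from compound 1 to compound 2 (0.48 log units; beyond the scatter) and a 3.5-fold lower number from compound 2 to compound 3 (0.54 log units; beyond the scatter) both set compound 2 apart as the weaker of the three in this assay.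

Compound 4 `CC(Sc1nc2c(cnn2C)c(=O)n1-c1ccccc1)c1cncnc1` is the next variation: pyrimidin-5-yl in place of 3-hydroxyphenyl on a saturated chain carbon bound to a saturated chain carbon and a sulfur. The step that bears most directly on it is a 3.5-fold lower number from compound 2 to compound 3 (0.54 log units; beyond the scatter), in which a pyridin-4-yl ring gave way to the 3-hydroxyphenyl ring and the number fell. Compound 4 moves in the opposite sense, from the 3-hydroxyphenyl ring back to a six-membered aromatic ring with two hetero atoms, so the expectation is a modest rise in the number in this assay, of about the size seen in that earlier step. For compound 4 the estimate is therefore 450 nM, with a range from 180 nM to 1100 nM. This expected value for compound 4 corresponds to a step of a 3.5-fold higher number from compound 3 to compound 4 (0.54 log units; beyond the scatter).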

Compound 4, half-maximal inhibitory concentration: 94 nM
Compound 4: middle estimate off by 4.8-fold (0.68 log units), on the high side; measured number below the stated range.
By their numbers in this assay, from the lowest: compounds 4, 3 and 1 (each within the scatter of the next); then compound 2.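

In this assay, for the compounds shown here, the earlier compounds left open whether the 3-hydroxyphenyl ring's hydroxyl was needed on the saturated chain carbon, and a 1.4-fold lower number from compound 3 to compound 4 (0.14 log units; within the scatter), within the scatter, shows that pyrimidin-5-yl, with no hydrogen-bond donor, performs on a par with it. Nitrogen in this ring is also not enough on its own to give a weaker inhibitor, since a 4.8-fold lower number from compound 2 to compound 4 (0.68 log units; beyond the scatter), beyond the scatter, separates two nitrogen-containing rings, so the kind of ring matters and not merely the presence of nitrogen. The further step, a 1.6-fold lower number from compound 1 to compound 4 (0.20 log units; within the scatter), also lies within the scatter, which places the 1-(pyrimidin-5-yl)ethyl and 1-phenylpropyl groups on the sulfur level with each other in this assay.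

Nothing available here explains why these rings compare as they do. Still open, as far as these compounds go, is how a pyridin-3-yl ring would fare at this position, and whether an amine or a carboxylic acid on the ring, or a propyl chain in place of the ethyl chain on the pyrimidin-5-yl compound, would hold the number at this level.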